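A few compounds are considered here, and "the series" means these few. Any claim that something is new, unique, unknown or untested is made for them only; others in the source may bear on it.

Measured compounds in the series:

compound 1, `CCCS(=O)(=O)Nc1ccc(F)c(C(=O)c2n[nH]c3ncc(-c4ccccc4O)cc23)c1F`: 9%
compound 2, `CCCS(=O)(=O)Nc1ccc(F)c(C(=O)c2n[nH]c3ncc(-c4ccccc4N)cc23)c1F`: 23%
compound 3, `CCCS(=O)(=O)Nc1ccc(F)c(C(=O)c2n[nH]c3ncc(-c4ccc(C(C)(C)C)cc4)cc23)c1F`: 46%

In an assay for binding affinity to dual specificity mitogen-activated protein kinase kinase 4 (Homo sapiens), read by KINOMEscan, tested at 100 nM (a higher number here means a weaker effect of the compound at the concentration tested, a lower number a stronger effect), compound 2 stands second highest of the three numbers. Its nearest neighbour is compound 1, separated by the step of a number 14 percentage points higher from compound 1 to compound 2 (beyond the scatter); the furthest is compound 3, separated by the step of a number 23 percentage points higher from compound 2 to compound 3 (beyond the scatter). Across the whole set, the step of a number 37 percentage points higher from compound 1 to compound 3 (beyond the scatter) is the largest change seen.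

Compound 4, `CCCS(=O)(=O)Nc1ccc(F)c(C(=O)c2n[nH]c3ncc(-c4cccc([N+](=O)[O-])c4)cc23)c1F`, is not yet measured. Relative to compound 2 the change is 3-nitrophenyl in place of 2-aminophenyl on an aromatic carbon.

Among the compounds with values here, the steps that bear on this change are those in which the 2-aminophenyl or the 2-hydroxyphenyl is exchanged for a differently substituted phenyl: a number 23 percentage points higher from compound 2 to compound 3 (beyond the scatter) and a number 37 percentage points higher from compound 1 to compound 3 (beyond the scatter). Both moved the read-out upward beyond the scatter, one modestly and one by a large amount. The change to 3-nitrophenyl is another exchange of the same kind, so a step upward in this assay is expected, of a size comparable to the modest step from compound 2 to compound 3 rather than the large one from compound 1. For compound 4 the expected step is a number 19 percentage points higher from compound 2 to compound 4 (beyond the scatter). Compound 4 is therefore estimated at 42%, with a range from 22% to 65%.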

Compound 4, a percentage reported as activity, at one concentration (the size of the read-out at that concentration, not a potency): 15%
The estimate for compound 4 lay 27 percentage points above the measured number, outside the stated range (below it).
By their numbers in this assay, from the lowest: compounds 1, 4 and 2 (each within the scatter of the next, the first and the last beyond it); then compound 3.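

In this assay, the 3-nitrophenyl group does not follow the upward steps seen earlier at this aromatic carbon: a number 8 percentage points lower from compound 2 to compound 4 (within the scatter), and a number 6 percentage points higher from compound 1 to compound 4 (within the scatter), while a number 31 percentage points lower from compound 3 to compound 4 (beyond the scatter). Among the compounds shown, a phenyl here therefore need not carry an amino or hydroxy group to stay within the scatter of compound 1 and compound 2, and compound 3, with its 4-(tert-butyl)phenyl, is the one that stands apart. No supporting data bear on why the 3-nitrophenyl and 4-(tert-butyl)phenyl groups part in this way.

Open, going by these compounds, is whether the separation of compound 3 belongs to the tert-butyl group itself or to where it sits on the ring, and whether the nitro group would give a similar number elsewhere on the ring. Also open, on these data alone, is how an unsubstituted phenyl, or a phenyl carrying a methoxy group or a carboxylic acid, would read at this aromatic carbon in this assay.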